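The source may report more compounds than this note shows. Statements on the series, on what has been measured and on what is new or still open speak of the compounds shown alone.

In an ADME assay on MT4 cells (Homo sapiens) for cytotoxicity, read by spectrophotometry, with a stated time of 5 days (a higher number here means that more compound is tolerated, a lower number that less compound is tolerated), compound 1 (`CONC(=S)N/N=C1\C(=O)N(CN2CCN(c3ccc(OC)cc3)CC2)c2ccc(C)cc21`) gives 324000 nM and compound 2 (`COc1ccc(N2CCN(CN3C(=O)/C(=N\NC(=S)NO)c4cc(Cl)ccc43)CC2)cc1`) gives 279000 nM and these two numbers lie within the usual scatter of each other. Compound 3 (`COc1ccc(N2CCN(CN3C(=O)/C(=N\NC(=S)NO)c4cc(C)ccc43)CC2)cc1`) differs from compound 2 in one place, with methyl in place of chloro on an aromatic carbon. Among the compounds with values here, no measured pair yet shows what this exchange does, so no step beyond the scatter is expected in this assay in either direction. Compound 3 is expected at 300000 nM with an estimated range from 150000 nM to 600000 nM as the likely span.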

Compound 3, half-maximal cytotoxic concentration: 321000 nM
Compound 3: the middle estimate sits 1.1-fold (0.03 log units) below what was measured; low and high end bracket the measured number.
By their numbers in this assay, from the lowest: compounds 2, 3 and 1 (each within the scatter of the next).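

In this assay, methyl in place of chloro on this aromatic carbon stays within the scatter (a 1.2-fold higher number from compound 2 to compound 3 (0.06 log units; within the scatter)), so the two groups cannot be told apart here. Hydrogen in place of methyl on an oxygen also stays within the scatter (a 1.0-fold lower number from compound 1 to compound 3 (0.00 log units; within the scatter)). Nothing measured here offers a reason for either result.

Still open, as far as these compounds go, is whether a different group on this aromatic carbon, such as an amine or a carboxylic acid, would change the number. The same question stands for a longer chain on the oxygen.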